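Methoxy in Place of Methyl in Compound 1

This account rests on a few compounds, and the source may have more. Where it says the series, first, only, none or still open, it means among the compounds named here.

For the measured compounds named here, in a functional assay on HeLa cells (Homo sapiens) for inhibition, read by sulforhodamine B assay, with a stated time of 74 h (a lower number here means a stronger inhibitor, a higher number a weaker inhibitor), compound 1 `Cc1ccc(S(=O)(=O)N2C(=O)COC23C=CC(=O)C=C3)cc1` gives 180 nM and holds the lowest number so far, with both of its measured steps beyond the scatter. Compound 3 `Cc1ccccc1S(=O)(=O)N1C(=O)COC12C=CC(=O)C=C2` gives 3720 nM in this assay as well. Compound 2 `Cc1ccc(S(=O)(=O)N2C(=O)C(C)OC23C=CC(=O)C=C3)cc1` shows > 10000 nM as its entry, which is a limit and not a number.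

Two measured steps show how far small edits can move the result. Methyl in place of hydrogen on a saturated ring carbon brings an at least 55-fold higher number from compound 1 to compound 2 (1.74 log units; beyond the scatter) and counts as large. 2-methylphenyl in place of 4-methylphenyl on a sulfonyl sulfur brings a 21-fold higher number from compound 1 to compound 3 (1.32 log units; beyond the scatter) and is large too.

Compound 4 `COc1ccc(S(=O)(=O)N2C(=O)COC23C=CC(=O)C=C3)cc1` keeps the core of compound 1 and carries methoxy in place of methyl on an aromatic carbon, para to a large group (methoxy in place of methyl on an aromatic carbon). The nearest guide is a 21-fold higher number from compound 1 to compound 3 (1.32 log units; beyond the scatter) on the same aromatic ring, yet there the methyl changes place, while here the place stays and the group changes. A far smaller step is therefore expected, leaning toward a somewhat higher number. The expected change is a 1.4-fold higher number from compound 1 to compound 4 (0.14 log units; within the scatter) as an estimate. For compound 4 the expected value is 250 nM with an estimated range from 80 nM to 900 nM in this assay.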

Compound 4, half-maximal inhibitory concentration: 880 nM
For compound 4 the middle estimate is 3.5-fold (0.55 log units) below the measured one, and the stated range covers the measured number.
By their numbers in this assay, from the lowest: compound 1; then compound 4; then compound 3. At a limit, above all of these: compound 2.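

Changing only the group on this aromatic carbon, with its place para to a large group unchanged, gives a 4.9-fold higher number from compound 1 to compound 4 (0.69 log units; beyond the scatter) in this assay, a step that counts as modest. The earlier step on this ring, a 21-fold higher number from compound 1 to compound 3 (1.32 log units; beyond the scatter), moved the methyl to another place, so it could not show whether the number also responds to the group itself at the original place; this step shows that it does, though by less than that large step. Methoxy brings an oxygen that methyl lacks and one more heavy atom, but nothing measured here separates these two differences or explains the rise in the number.

The compounds shown give only methyl and methoxy at this place, so they leave open whether the number rises with any replacement of methyl or only with this one. An ethyl group, a chlorine atom or an amine on the same aromatic carbon would each test this further, as would a plain hydrogen there, with the rest of the molecule kept as it is.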